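A methyl added to the anilino ring of compound 1

The source may report more compounds than this note shows. Statements on the series, on what has been measured and on what is new or still open speak of the compounds shown alone.

Compound 1, with the structure `C=CC(=O)Nc1cccc(NC(=O)CSc2nc(Nc3ccccc3)c3ccccc3n2)c1`, was tested in a functional assay on MDA-MB-231 cells (Homo sapiens) for inhibition, read by MTT assay, with a stated time of 72 h (a higher number here means a weaker inhibitor, a lower number a stronger inhibitor), and gives 10200 nM. Its two neighbours differ from it in the group on the amide-type nitrogen: compound 2 `O=C(CSc1nc(Nc2ccccc2)c2ccccc2n1)Nc1ccc(Br)cc1` gives 11500 nM, and compound 3 `O=C(CSc1nc(Nc2ccccc2)c2ccccc2n1)Nc1ccc(C(F)(F)F)cc1` gives 11100 nM. The step of a 1.1-fold higher number from compound 1 to compound 2 (0.05 log units; within the scatter) and the step of a 1.1-fold higher number from compound 1 to compound 3 (0.04 log units; within the scatter) both stay within the scatter, as does the step of a 1.0-fold lower number from compound 2 to compound 3 (0.02 log units; within the scatter), so the three numbers cannot be ranked, and compound 1 merely has the lowest of the three.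

Compound 4, with the structure `C=CC(=O)Nc1cccc(NC(=O)CSc2nc(Nc3cccc(C)c3)c3ccccc3n2)c1`, differs from compound 1 at the other end of the shared core: methyl in place of hydrogen on an aromatic carbon, the place being meta to a large group, so that anilino becomes (3-methylphenyl)amino. Among the measured compounds shown here, none of the measured steps touches this ring; they only show that the swapped groups so far moved this assay very little. For the measured compounds named here, with no step to lean on, the expected change in this assay is none beyond the scatter, and for compound 4 the estimated step of a 1.1-fold lower number from compound 1 to compound 4 (0.03 log units; within the scatter) is small. Compound 4 is therefore expected to give about 9500 nM in this assay, within the range 4000 nM to 22000 nM.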

Compound 4, half-maximal inhibitory concentration: 16800 nM
Estimate against measurement, compound 4: 1.8-fold (0.25 log units) below, within the range that was stated.
By their numbers in this assay, from the lowest: compounds 1, 3, 2 and 4 (each within the scatter of the next).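

Among the compounds shown here, compound 4 is the first compound here with a change on the anilino ring, whereas the earlier steps all concerned the group on the amide-type nitrogen. In this assay the added methyl gives a 1.6-fold higher number from compound 1 to compound 4 (0.22 log units; within the scatter), so this single methyl, meta to a large group, has no effect that can be told apart from the ordinary spread of repeated measurements. No measured information is available to explain this result.

The compounds shown leave open whether a different group at this place, such as an amine, a carboxylic acid or a longer chain, would shift the number beyond the scatter. They also leave open whether a methyl elsewhere on the anilino ring would read the same as this one.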